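Changing the Aryl Group on the Sulfonamide of Compound 3

This account rests on a few compounds, and the source may have more. Where it says the series, first, only, none or still open, it means among the compounds named here.

Three compounds have been measured in a functional assay on HeLa cells (Homo sapiens) for inhibition, read by MTT assay, with a stated time of 72 h; a higher number here means a weaker inhibitor, a lower number a stronger inhibitor:

Compound 1 `O=c1cc(Cn2cc(CCCCl)nn2)c2ccc(O)cc2o1`: 49600 nM
Compound 2 `O=c1cc(Cn2cc(CCc3ccccc3)nn2)c2ccc(O)cc2o1`: 35100 nM
Compound 3 `Cc1ccc(S(=O)(=O)NCc2cn(Cc3cc(=O)oc4cc(O)ccc34)nn2)cc1`: 55700 nM

Compound 3 gives the highest of these three numbers, but its gaps to compound 1 and to compound 2 both lie within the usual scatter, so the three cannot be placed in any order. Compound 4 `O=c1cc(Cn2cc(CNS(=O)(=O)c3ccc(F)cc3Cl)nn2)c2ccc(O)cc2o1` differs from compound 3 in one place: 2-chloro-4-fluorophenyl in place of 4-methylphenyl on a sulfonyl sulfur. Going by the values given here, the only measured step, a 1.4-fold lower number from compound 1 to compound 2 (0.15 log units; within the scatter), concerns the end of a saturated chain and not the group on the sulfonyl sulfur, and it too lies within the scatter. Among the compounds with values here, no measured step bears directly on the change made here. On this basis, the step from compound 3 to compound 4 in this assay is expected to be a 1.1-fold lower number from compound 3 to compound 4 (0.05 log units; within the scatter), that is, nothing beyond the scatter in either direction. Compound 4 is therefore estimated at 50000 nM in this assay, with a range from 20000 nM to 130000 nM.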

Compound 4, half-maximal inhibitory concentration: 74900 nM
Compound 4: middle estimate off by 1.5-fold (0.18 log units), on the low side; the measured number falls inside the stated range.
By their numbers in this assay, from the lowest: compounds 2, 1, 3 and 4 (each within the scatter of the next, the first and the last beyond it).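

Going by these compounds alone, compound 4 gives the only direct reading on the group on the sulfonyl sulfur, and in this assay the exchange of 4-methylphenyl for 2-chloro-4-fluorophenyl amounts to a 1.3-fold higher number from compound 3 to compound 4 (0.13 log units; within the scatter) and so does not separate the two compounds. At this position, then, an aryl ring bearing chlorine and fluorine gives a number that cannot be told apart from that of the ring bearing methyl, although this single pair sets no trend for the position. Nothing available accounts for this result.

The compounds shown leave open whether an unsubstituted phenyl, a methyl or a morpholine on the sulfonyl sulfur would move the number beyond the scatter. They also leave open whether an amide in place of the sulfonamide would do so.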